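Removing a hydroxy from a weak nitric oxide inhibitor

The source may hold more compounds than are shown below. What is called first, only, known or untested is meant among the compounds shown, and "the series" means these compounds.

The series is built on a shared core bearing a dihydroxyphenyl group, and its members are tested in a functional assay on RAW264.7 cells (Rattus norvegicus) for inhibition, with RAW264.7 (Mus musculus) as the target, read by Griess assay, with stated times of 2 h and 16 h; on this read-out lower numbers stand for stronger inhibition and higher numbers for weaker inhibition. Compound 1 `COc1ccc2c(c1)C(=O)[C@H](O)[C@@H](c1cccc(O)c1O)O2` is reported only as a limit of the assay, > 100000 nM. Compound 2 `COc1cc2c(cc1OC)C(=O)[C@@H](O)[C@H](c1cccc(O)c1O)O2` likewise reaches only the limit of > 100000 nM. For the measured compounds named here, compound 3 `O=C1c2c(O)cccc2O[C@H](c2cccc(O)c2O)[C@H]1O` is the one member that gives a number in this assay, 77700 nM, so it stands alone as the only measured value among the three. The other two sit at the limit described in the limit of > 100000 nM in this assay, at which 2 of the 3 values shown sit.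

Compound 4 `O=C1c2ccccc2O[C@H](c2cccc(O)c2O)[C@H]1O` has not yet been measured in this assay. It differs from compound 3 in one place: hydrogen in place of hydroxy on an aromatic carbon. Going by the values given here, no step between two measured compounds is available to guide the expectation, so the size of the step from compound 3 to compound 4 is uncertain. The change is expected to be small, not beyond the usual scatter, with a slight lean toward weaker inhibition, and the step is estimated as a 1.2-fold higher number from compound 3 to compound 4 (0.06 log units; within the scatter). Compound 4 is therefore expected to give about 90000 nM in this assay, within a range from 40000 nM to 200000 nM.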

Compound 4, half-maximal inhibitory concentration: > 100000 nM
Compound 4: only a limit was reported (the forecaster's own chance of this, stated with the estimate: 35%); at least 1.1-fold (0.04 log units) between middle value and limit.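

Taking the hydroxy off this aromatic carbon gives the series its one readable step in this assay, an at least 1.2-fold higher number from compound 3 to compound 4 (0.10 log units; that floor lies within the scatter). That figure is only a floor: the true change may stay within the scatter or go well beyond it, and the data do not separate the two. The step from compound 1 cannot be read, and compound 3 alone now carries a number, with every other member at a single limit: the limit of > 100000 nM in this assay, at which 3 of the 4 values shown sit.

As far as these compounds go, whether an amine or a chlorine atom on this aromatic carbon would give a number, as compound 3 does, or only a limit, stays open. From the compounds shown here alone, how far compound 4 really lies from compound 3 also stays open.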